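Removing the ester from a pyrrole-based lactone inhibitor

The source may report more compounds than this note shows. Statements on the series, on what has been measured and on what is new or still open speak of the compounds shown alone.

Of the compounds shown here, three of a shared core have been measured in an assay for inhibition of 3-hydroxy-3-methylglutaryl-coenzyme A reductase (Rattus norvegicus); a higher number here means a weaker inhibitor, a lower number a stronger inhibitor. Compound 1, `CCOC(=O)c1c(-c2ccccc2)c(-c2ccccc2)n(CC[C@@H]2C[C@@H](O)CC(=O)O2)c1C`, gives 4000 nM. Compound 2, `CCOC(=O)c1c(C(=O)OCC)c(C(C)C)n(CC[C@@H]2C[C@@H](O)CC(=O)O2)c1-c1ccc(F)cc1`, gives 350 nM. Compound 3, `CCOC(=O)c1c(-c2ccccc2)c(C(C)C)n(CC[C@@H]2C[C@@H](O)CC(=O)O2)c1-c1ccc(F)cc1`, gives 50 nM, the lowest of the three numbers. For the measured compounds named here, the only measured single-point step is a 7.0-fold lower number from compound 2 to compound 3 (0.85 log units; beyond the scatter), and it was of modest size.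

Compound 4, `CC(C)c1c(-c2ccccc2)cc(-c2ccc(F)cc2)n1CC[C@@H]1C[C@@H](O)CC(=O)O1`, differs from compound 3 by hydrogen in place of ethoxycarbonyl on an aromatic carbon. Going by the values given here, no measured step covers the loss of this ethoxycarbonyl group in exchange for hydrogen; the one step recorded concerns a phenyl taking the place of an ethoxycarbonyl at a different aromatic carbon, so it bears on the present change only loosely. The data show that the substitution pattern around this ring alters the numbers by well over the scatter, and a change removing a whole group is therefore expected to move the number, most likely upward, by a 4.0-fold higher number from compound 3 to compound 4 (0.60 log units; beyond the scatter). Compound 4 is estimated to give 200 nM, with a range from 60 nM to 700 nM.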

Compound 4, half-maximal inhibitory concentration: 120 nM
The estimate for compound 4 lay 1.7-fold (0.22 log units) above the measured number; measured number inside the range.
By their numbers in this assay, from the lowest: compound 3; then compound 4; then compound 2; then compound 1.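

In this assay, replacing the ethoxycarbonyl with hydrogen on the aromatic carbon next to the ring atom that bears a 4-fluorophenyl group gives a 2.4-fold higher number from compound 3 to compound 4 (0.38 log units; beyond the scatter). The ethoxycarbonyl at this carbon therefore counts towards the lower number of compound 3, but the step is modest, and compound 4 keeps a number of 120 nM with only hydrogen there, so the group is not indispensable. No accompanying measurement accounts for this step.

Going by these compounds, it remains open whether a methyl, a carboxylic acid, an amide or a nitrile at this carbon would bring the number down to that of compound 3 or take it lower still. On these data alone, it is also open whether the same exchange would have a step of similar size with other groups elsewhere on the shared core.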